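A slightly larger group on the carbonyl carbon

The source may hold more compounds than are shown below. What is called first, only, known or untested is meant among the compounds shown, and "the series" means these compounds.

Within the data shown here, two related compounds share a core, and only one has a usable number so far. In an ADME assay on microsomes from liver (Homo sapiens) for metabolic stability, with a stated time of 10 min (a lower number here means that less of the compound is left, a higher number that more of the compound is left), compound 1 (`C[C@]1(C(=O)O)CC[C@H](C(=O)N2CC[C@](c3ccc(C(F)(C(F)(F)F)C(F)(F)F)cc3)(S(=O)(=O)c3ccc(F)cc3)C2)CC1`) gives 97%, which means that very little of it was lost during the test. For compound 2 (`O=C(O)C12CCC(C(=O)N3CC[C@](c4ccc(C(F)(C(F)(F)F)C(F)(F)F)cc4)(S(=O)(=O)c4ccc(F)cc4)C3)(CC1)C2`) the result reads "not determined" (no result reported), so compound 2 has no place on this scale and cannot serve as a starting value.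

Compound 3 (`O=C(O)C12CCC(C(=O)N3CC[C@](c4ccc(C(F)(C(F)(F)F)C(F)(F)F)cc4)(S(=O)(=O)c4ccc(F)cc4)C3)(CC1)CC2`) differs from compound 2 in one place: a group of 11 heavy atoms (9 carbon, 2 oxygen; 2 six-membered non-aromatic rings of carbon only) in place of a group of 10 heavy atoms (8 carbon, 2 oxygen; 2 five-membered non-aromatic rings of carbon only), on a carbonyl carbon. The group sits on a carbonyl carbon whose other neighbour is an amide-type nitrogen in a ring, and the rest of the structure stays the same.

Among the measured compounds shown here, without a number for compound 2, no measured step leads to compound 3, and the only guide is the result for compound 1, at 97%. In this assay I therefore expect compound 3 to stay close to compound 1, with no difference beyond the usual scatter, although a modest drop remains possible. The estimated value for compound 3 is 90%, with an expected range from 70% to 100%.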

Compound 3, percent of the compound remaining: 100%
Estimate against measurement, compound 3: 10 percentage points below; low and high end bracket the measured number.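

In this assay the change of group on the carbonyl carbon gives a number 3 percentage points higher from compound 1 to compound 3 (within the scatter), so the group with 2 six-membered non-aromatic rings of carbon only and the group with one six-membered non-aromatic ring of carbon only cannot be told apart in this test. Among these compounds, this is the first measured step at this position, and it shows that the position accepts this exchange of one ring group for another without a change beyond the normal spread of repeated measurements. Compound 2 has no number, so the step from its 2 five-membered rings to the six-membered rings of compound 3 cannot be read, and nothing available explains the result for compound 3.

All the compounds shown keep a carboxylic acid on the group at this position, so it remains open whether the result would hold with an amine or a methyl ester in its place. As far as these compounds go, it also remains open whether a group without rings, such as a longer open carbon chain ending in a carboxylic acid, would behave like the ring groups of compound 1 and compound 3.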